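Chloro ring isomers on the anilino nitrogen

The source may report more compounds than this note shows. Statements on the series, on what has been measured and on what is new or still open speak of the compounds shown alone.

Measured in a functional assay on MGC-803 cells (Homo sapiens) for inhibition, read by MTT assay, with a stated time of 72 h; on this read-out lower numbers stand for stronger inhibition and higher numbers for weaker inhibition:
- compound 1, `O=C(CSc1nc(Nc2ccccc2)c2ccccc2n1)Nc1ccccc1F`: 10700 nM
- compound 2, `C=CC(=O)Nc1cccc(NC(=O)CSc2nc(Nc3ccccc3Br)c3ccccc3n2)c1`: 12800 nM
- compound 3, `C=CC(=O)Nc1cccc(NC(=O)CSc2nc(Nc3cccc(Cl)c3)c3ccccc3n2)c1`: 7830 nM

Compound 3 shows the lowest of the three numbers, yet its gaps to compound 1 and to compound 2 both sit within the scatter, so the three compounds cannot be ranked on these data. Among the compounds with values here, the only single-point step available, a 1.6-fold lower number from compound 2 to compound 3 (0.21 log units; within the scatter), exchanges one halogenated phenyl on the same nitrogen for another and stays within the scatter.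

Compound 4, `C=CC(=O)Nc1cccc(NC(=O)CSc2nc(Nc3ccc(Cl)cc3)c3ccccc3n2)c1`, differs from compound 3 in that it has the same atoms joined differently: 4-chlorophenyl in place of 3-chlorophenyl on a nitrogen on an aromatic ring. Within the data shown here, this resembles the halogenated-phenyl exchange in the one measured step, which did not move the read-out beyond the scatter; no measured pair addresses a 4-chlorophenyl directly. The expectation for compound 4 is therefore no step beyond the scatter, a 1.0-fold higher number from compound 3 to compound 4 (0.01 log units; within the scatter), so compound 4 is estimated at 8000 nM, with a range from 3500 nM to 18000 nM.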

Compound 4, half-maximal inhibitory concentration: 14300 nM
Estimate against measurement, compound 4: 1.8-fold (0.25 log units) below; low and high end bracket the measured number.
By their numbers in this assay, from the lowest: compounds 3, 1, 2 and 4 (each within the scatter of the next).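

In this assay, 4-chlorophenyl in place of 3-chlorophenyl on a nitrogen on an aromatic ring gives a 1.8-fold higher number from compound 3 to compound 4 (0.26 log units; within the scatter), so this change, with the same atoms joined differently, does not separate the two isomers. The exchange of 2-bromophenyl for 4-chlorophenyl at the same place gives a 1.1-fold higher number from compound 2 to compound 4 (0.05 log units; within the scatter), which leaves compound 2, compound 3 and compound 4 unresolved on this read-out, with no effect of halogen identity or ring position demonstrated among them. No supporting data are available to account for these steps.

Open, from the compounds shown here alone, is whether a phenyl carrying a carboxylic acid or an amine in place of the halogen would move the read-out beyond the scatter at this nitrogen. Also open, going by these compounds, is how 2-chlorophenyl would compare at the same place.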